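One (1,4-dioxan-2-yl)methyl arm removed from compound 1

A few compounds are considered here, and "the series" means these few. Any claim that something is new, unique, unknown or untested is made for them only; others in the source may bear on it.

Compound 1 `C1CSC(CC[C@@H]2COCCO2)(C[C@@H]2COCCO2)SC1` is the starting point. In an ADME assay on BHK cells (Mesocricetus auratus) for cytotoxicity, read by XTT assay (a higher number here means that more compound is tolerated, a lower number that less compound is tolerated), compound 1 gives only a limit, > 1000000 nM. Its companion compound 2 `C1CSC(C[C@H]2COCCO2)(C[C@@H]2COCCO2)SC1` likewise gives only a limit in this assay, > 1000000 nM. The step that the two limits leave unreadable from compound 1 to compound 2 therefore cannot be sized, as shown by the limit of > 1000000 nM in this assay, at which 2 of the 2 values shown sit. Compound 3 `C1CSC(CC[C@@H]2COCCO2)SC1` differs from compound 1 by hydrogen in place of (1,4-dioxan-2-yl)methyl on a saturated ring carbon. For the measured compounds named here, no measured step is readable here, so no direction can be expected beyond the scatter. Compound 3 is expected to give 1500000 nM, between 500000 nM and 5000000 nM. The step that the limit leaves unreadable from compound 1 to compound 3 is thus expected to be of no readable size.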

Compound 3, half-maximal cytotoxic concentration: > 1000000 nM
Compound 3 gave a limit, no number (the forecaster's own chance of this, stated with the estimate: 85%); the middle value lies beyond the limit too.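

In this assay, for the compounds shown here, compound 3, like compound 1, gives only a limit, so no step between them can be read: the limit of > 1000000 nM in this assay, at which 3 of the 3 values shown sit. The compounds shown leave open at what concentration any of them becomes cytotoxic, and whether removing the (1,4-dioxan-2-yl)methyl arm alters that.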